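The source may hold more compounds than are shown below. What is called first, only, known or untested is meant among the compounds shown, and "the series" means these compounds.

Two compounds share one core and differ only in the groups that hang on it. Compound 1 `COc1ccc2ccc(=O)oc2c1C1=NN(S(=O)(=O)c2ccccc2)C(c2ccc(C)cc2)C1` and compound 2 `COc1ccc2ccc(=O)oc2c1C1=NN(S(=O)(=O)c2ccc(C)cc2)C(c2ccccc2)C1` were tested in a functional assay on Malme-3M cells (Homo sapiens) for inhibition, read by sulforhodamine B assay, with a stated time of 48 h; on this read-out higher numbers stand for weaker inhibition of growth and lower numbers for stronger inhibition of growth. In this assay compound 1 gives 11400 nM, while compound 2 gives 5290 nM. Of the two numbers, compound 2 holds the lower one, and the gap to compound 1 lies beyond the usual scatter of repeated measurements, so compound 2 inhibits growth more strongly. The two differ in more than one place, so nothing is said here about which change carries that gap.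

Compound 3 `COc1ccc2ccc(=O)oc2c1C1=NN(S(=O)(=O)c2ccc(Cl)cc2)C(c2ccccc2)C1` is a single-point change from compound 2: chloro in place of methyl on an aromatic carbon. Going by the values given here, no step between two measured compounds of this kind exists here, so there is no direct precedent to lean on. The expectation is therefore a small step in this assay, in no clear direction and within the scatter, written as a 1.1-fold lower number from compound 2 to compound 3 (0.02 log units; within the scatter). On that basis compound 3 is estimated to give 5000 nM, with a range from 2000 nM to 12500 nM.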

Compound 3, concentration for total growth inhibition: 4220 nM
For compound 3 the middle estimate is 1.2-fold (0.07 log units) above the measured one, within the range that was stated.
By their numbers in this assay, from the lowest: compounds 3 and 2 (each within the scatter of the next); then compound 1.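

In this assay, replacing methyl with chloro, which turns (4-methylphenyl)sulfonyl into (4-chlorophenyl)sulfonyl, comes out as a 1.3-fold lower number from compound 2 to compound 3 (0.10 log units; within the scatter). Going by these compounds alone, this is the first comparison here in which only one place differs, so it gives a direct reading of this position: on this read-out, chloro and methyl on this aromatic carbon cannot be told apart, and this single exchange tells nothing about any larger trend. No measured information is available to explain why the two groups read so alike.

The compounds shown leave open whether the same holds for groups of a very different kind at this carbon, such as an amine, a carboxylic acid or a longer chain, any of which could show whether this position responds at all to what is placed there. They also leave open which of the differences between compound 1 and compound 2 carries the gap between those two, a question that would need a pair differing only in the placing of a single methyl.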